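Aryl glycinamide lactones: fluoro in place of isopropyl

The source may hold more compounds than are shown below. What is called first, only, known or untested is meant among the compounds shown, and "the series" means these compounds.

Working notes on the series. In a functional assay on MCF7 cells (Homo sapiens) for antiproliferative activity, read by MTT assay, with a stated time of 72 h (on this read-out higher numbers stand for weaker inhibition and lower numbers for stronger inhibition), compound 1 `O=C1OCC[C@@H]1NC(=S)SCCOc1ccc([N+](=O)[O-])cc1` gives only a limit, > 64000 nM. Compound 2 `CC(C)c1ccc(NCC(=O)N[C@H]2CCOC2=O)cc1` likewise gives only a limit in this assay, > 64000 nM. Compound 2 thus sits at the limit of > 64000 nM in this assay, at which 2 of the 2 values shown sit, and nothing in the numbers shown separates it from compound 1. Compound 3 `O=C(CNc1ccc(F)cc1)N[C@H]1CCOC1=O` differs from compound 2 by fluoro in place of isopropyl on an aromatic carbon. For the measured compounds named here, no measured step bears on this change, and no step beyond the scatter is expected in either direction. The expected step from compound 2 to compound 3 is a step that the limit leaves unreadable from compound 2 to compound 3. For compound 3 the estimate is 80000 nM, with a range from 30000 nM to 200000 nM.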

Compound 3, half-maximal inhibitory concentration: > 64000 nM
Compound 3: a limit, no number (the forecaster's own chance of this, stated with the estimate: 85%); the middle value is on the limit's open side.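

No step can be read from compound 2 to compound 3, since both stand only as limits in this assay: the limit of > 64000 nM in this assay, at which 3 of the 3 values shown sit.

The compounds shown leave open whether fluoro in place of isopropyl on an aromatic carbon changes activity at all.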